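Swapping the Chain End: Ethynyl for Ethyl

The source may hold more compounds than are shown below. What is called first, only, known or untested is meant among the compounds shown, and "the series" means these compounds.

Compound 1 `C=CCc1cc(C(C)=O)c(O)cc1OCCCC#N`: 47%
Compound 2 `C=CCc1cc(C(C)=O)c(O)cc1OCCCCCC`: 50%

In an assay on isolated protein for inhibition of leukotriene B4 receptor 1 (Homo sapiens), tested at 10 uM (a lower number here means less inhibition, a higher number more inhibition at the concentration tested (going by the name of the read-out)), compound 1 gives 47% and compound 2 gives 50%; the two lie within the scatter of each other, as the step of a number 3 percentage points higher from compound 1 to compound 2 (within the scatter) shows. Compound 3 `C#CCCCCOc1cc(O)c(C(C)=O)cc1CC=C` differs from compound 2 only at the chain end: ethynyl in place of ethyl on a saturated chain carbon, four bonds along the chain from an oxygen on an aromatic ring. Going by the values given here, the single measured step that touched this chain end, a number 3 percentage points higher from compound 1 to compound 2 (within the scatter), stayed within the scatter, so the step of a number 2 percentage points lower from compound 2 to compound 3 (within the scatter) is expected to be small as well. Compound 3 is therefore estimated at 48%, within a range of 30% to 65%.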

Compound 3, a percentage reported as inhibition, at one concentration (the size of the read-out at that concentration, not a potency): 74%
Estimate against measurement, compound 3: 26 percentage points below, outside the stated range (above it).
By their numbers in this assay, from the lowest: compounds 1 and 2 (each within the scatter of the next); then compound 3.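

In this assay this chain end proves sensitive after all: ethynyl and ethyl have the same heavy-atom count, yet the step is a number 24 percentage points higher from compound 2 to compound 3 (beyond the scatter). The other comparison, propargyl in place of cyano, gives a number 27 percentage points higher from compound 1 to compound 3 (beyond the scatter), so a triple bond alone is not enough, since the nitrile of compound 1 also carries one. No available evidence explains the gain. Going by these compounds, it remains open whether an amine or a carboxylic acid at the chain end, or a longer chain carrying the ethynyl, would hold this level.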